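The compounds below may be only part of what the source reports. "The series", "measured", "known", "first", "only" and "open" are said of these compounds alone.

Measured so far in an assay on isolated protein for agonist activity at Bile acid receptor (Homo sapiens), read by AlphaScreen, with a stated time of 30 min; on this read-out higher numbers stand for larger maximal responses and lower numbers for smaller maximal responses:
compound 1 `Cc1ccccc1-n1nc(C)c2c1NC(=O)[C@H](C)S[C@@H]2c1ccc(-c2ccoc2)cc1`: 40%
compound 2 `Cc1nn(-c2ccccc2I)c2c1C(c1ccc(Oc3ccccc3)cc1)SC(C)C(=O)N2`: 130%
compound 3 `COc1ccccc1-c1ccc([C@H]2S[C@@H](C)C(=O)Nc3c2c(C)nn3-c2ccccc2C)cc1`: 50%

In this assay compound 3 gives 50%, the second highest of the three values; compound 1 with 40% lies within the scatter of it, and compound 2 with 130% lies well beyond it. Compound 4 `COc1cccc(Oc2ccc([C@H]3S[C@@H](C)C(=O)Nc4c3c(C)nn4-c3ccccc3C)cc2)c1` differs from compound 3 by 3-methoxyphenoxy in place of 2-methoxyphenyl on an aromatic carbon. For the measured compounds named here, the only measured step at this aromatic carbon is a number 10 percentage points higher from compound 1 to compound 3 (within the scatter), which stays within the scatter. Going by the values given here, compound 2 differs from compound 3 in more than one place, so its high value gives no defined step for this change. Among the compounds with values here, with one flat step and no directly comparable pair, compound 4 is expected near compound 3, leaning upward, estimated at 65% with a range of 35% to 105%, a step of a number 15 percentage points higher from compound 3 to compound 4 (beyond the scatter).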

Compound 4, largest response reached (reported as efficacy), in percent of the reference or control that the assay uses: 120%
The estimate for compound 4 lay 55 percentage points below the measured number, outside the stated range (above it).
By their numbers in this assay, from the lowest: compounds 1 and 3 (each within the scatter of the next); then compounds 4 and 2 (each within the scatter of the next).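

In this assay the aromatic carbon para to a large group is not a flat position: a number 70 percentage points higher from compound 3 to compound 4 (beyond the scatter), and a number 80 percentage points higher from compound 1 to compound 4 (beyond the scatter). Among the groups compared directly here, only 3-methoxyphenoxy moves the response beyond the scatter. No data on hand bear on the reason for this rise.

The compounds shown leave open whether the linking oxygen or the methoxy group carries the change, as both differ in this single step. Going by these compounds, how a benzyloxy group or an amine would read at this carbon also remains open.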